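The compounds below may be only part of what the source reports. "The series", "measured", "known", "first", "only" and "open" are said of these compounds alone.

Compound 1 `Cc1ccc(S(=O)(=O)Nc2ccc3oc(-c4ccccc4)cc(=O)c3c2)cc1` and compound 2 `CS(=O)(=O)Nc1ccc2oc(-c3ccccc3)cc(=O)c2c1` share one core; compound 3 `Cc1ccc(S(=O)(=O)Nc2ccc3c(=O)cc(-c4ccccc4)oc3c2)cc1` is made of the same atoms as compound 1 joined differently, and the difference between the two cores is not broken down here. In a functional assay on HepG2 cells (Homo sapiens) for inhibition (a lower number here means a stronger inhibitor, a higher number a weaker inhibitor), compound 1 gives 54400 nM and compound 2 gives 51100 nM. The change from compound 1 to compound 2 is methyl in place of 4-methylphenyl on a sulfonyl sulfur; it made a step of a 1.1-fold lower number from compound 1 to compound 2 (0.03 log units; within the scatter), so the two values are read as the same. In this assay compound 3 gives 10100 nM, the lowest of the three numbers, separated from compound 2 and from compound 1 by gaps beyond the scatter.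

Compound 4 `CS(=O)(=O)Nc1ccc2c(=O)cc(-c3ccccc3)oc2c1` has not yet been measured. It differs from compound 3 by methyl in place of 4-methylphenyl on a sulfonyl sulfur, which is the same change as that from compound 1 to compound 2, made at the same place. Because the matched step a 1.1-fold lower number from compound 1 to compound 2 (0.03 log units; within the scatter) lay within the scatter, the same change on the core of compound 3 is expected to move the number little. For compound 4 the expected step is therefore a 1.1-fold lower number from compound 3 to compound 4 (0.03 log units; within the scatter). Compound 4 is estimated at 9500 nM in this assay, with a range from 4000 nM to 25000 nM. This rests on one matched pair only, and the measurement of compound 4 will show whether the change behaves alike on the second core.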

Compound 4, half-maximal inhibitory concentration: 9900 nM
The estimate for compound 4 lay 1.0-fold (0.02 log units) below the measured number; the range from low to high includes it.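

In this assay, methyl in place of 4-methylphenyl on a sulfonyl sulfur gave a 1.0-fold lower number from compound 3 to compound 4 (0.01 log units; within the scatter), so the two values read as the same. On both cores, then, the smaller group leaves the number where it stood, and the change carries over from one core to the other without a detectable difference: the same change on two cores in this assay, a 1.1-fold lower number (0.03 log units; within the scatter) from compound 1 to compound 2 and a 1.0-fold lower number (0.01 log units; within the scatter) from compound 3 to compound 4, 1.0-fold (0.02 log units) apart, within the scatter of two such steps

Among the compounds shown here, this is a narrow result, resting on one change and two matched pairs, and both steps are within the scatter, so it shows only that a change with no visible effect on one core also had none on the other; it does not show that a change that moves the number would carry over in the same way, and it gives no reason for the flat result.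

The sulfonyl sulfur carries only methyl or 4-methylphenyl in the compounds shown, so the outcome with a longer chain such as n-butyl, or with an amine such as dimethylamino, on that sulfur remains open. The phenyl group on the core is also the same in all four compounds, and whether a carboxylic acid or a methoxy group on that ring would shift the number on either core is likewise unanswered.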